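Fluoro Substitution on the Nitrophenyl Amide of Compound 3

The compounds below may be only part of what the source reports. "The series", "measured", "known", "first", "only" and "open" are said of these compounds alone.

In a functional assay on A549 cells (Homo sapiens) for cytotoxicity, read by MTT assay (on this read-out higher numbers stand for weaker inhibition and lower numbers for stronger inhibition), compound 3 `CCn1cc(C(=O)Nc2cccc([N+](=O)[O-])c2)c(=O)c2cc(F)c(N3CCNC(C)C3)c(F)c21` gives 3240 nM, the lowest of the three numbers. Compound 2 `CCn1cc(C(=O)Nc2ccccc2O)c(=O)c2cc(F)c(N3CCNC(C)C3)c(F)c21` gives 24800 nM and compound 1 `CCn1cc(C(=O)Nc2ccccc2)c(=O)c2cc(F)c(N3CCNC(C)C3)c(F)c21` gives 39300 nM; the steps of a 7.7-fold lower number from compound 2 to compound 3 (0.88 log units; beyond the scatter) and a 12-fold lower number from compound 1 to compound 3 (1.08 log units; beyond the scatter) both lie beyond the scatter, whereas a 1.6-fold lower number from compound 1 to compound 2 (0.20 log units; within the scatter) does not. Compound 4 `CCn1cc(C(=O)Nc2cc([N+](=O)[O-])ccc2F)c(=O)c2cc(F)c(N3CCNC(C)C3)c(F)c21` differs from compound 3 by fluoro in place of hydrogen on an aromatic carbon, placed ortho to a large group and para to a nitro group. For the measured compounds named here, none of the measured steps adds a fluoro; the one large step, a 12-fold lower number from compound 1 to compound 3 (1.08 log units; beyond the scatter), concerns the nitro group, which compound 4 retains. A change within the scatter is therefore expected, a 1.1-fold lower number from compound 3 to compound 4 (0.03 log units; within the scatter), with no clear direction. Compound 4 is estimated at 3000 nM, between 1000 nM and 10000 nM.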

Compound 4, half-maximal inhibitory concentration: 1700 nM
For compound 4 the middle estimate is 1.8-fold (0.25 log units) above the measured one, within the range that was stated.
By their numbers in this assay, from the lowest: compounds 4 and 3 (each within the scatter of the next); then compounds 2 and 1 (each within the scatter of the next).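

In this assay fluoro in place of hydrogen, ortho to a large group and para to a nitro group, gives a 1.9-fold lower number from compound 3 to compound 4 (0.28 log units; within the scatter) and so shows that this position takes the fluoro without a shift beyond the scatter. Against the compounds without a nitro group, a 15-fold lower number from compound 2 to compound 4 (1.16 log units; beyond the scatter) and a 23-fold lower number from compound 1 to compound 4 (1.36 log units; beyond the scatter) are both large, so the low number of the nitro series survives the added fluoro. Nothing shown here explains these numbers. On these data alone, whether chloro, methoxy or an amine at this position would read the same stays open, as does the effect of fluoro on the phenyl amide without its nitro group.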